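Closing a Propylamino Chain into an Azetidine Ring

The compounds below may be only part of what the source reports. "The series", "measured", "known", "first", "only" and "open" are said of these compounds alone.

Compound 1 `CNc1ncnc2c1ncn2Cc1ccccc1C(F)(F)F` gives 20 mg/kg
Compound 2 `CNc1ncnc2c1ncn2Cc1c(F)cccc1Cl` gives 12.5 mg/kg
Compound 3 `CCCNc1ncnc2c1ncn2Cc1ccccc1F` gives 5.1 mg/kg

These three compounds were tested in a functional assay on the whole organism with Rattus norvegicus as the target, in the maximal electroshock model; on this read-out higher numbers stand for an effect only at larger amounts of compound and lower numbers for an effect already at smaller amounts. Among them, compound 3 has the lowest number; compound 2 sits beyond the scatter above it, and compound 1 further still. Compound 4 `Fc1ccccc1Cn1cnc2c(N3CCC3)ncnc21` has not yet been measured in this assay. It differs from compound 3 in one place: azetidin-1-yl in place of propylamino on an aromatic carbon. Among the measured compounds shown here, no pair of measured compounds shares this kind of change, so no measured step is available to guide the expectation. The step is expected to be small, toward a slightly higher number, and may lie within the scatter: a 1.4-fold higher number from compound 3 to compound 4 (0.14 log units; within the scatter). Because compound 3 gives 5.1 mg/kg, compound 4 is expected to give 7 mg/kg, within a range from 3 mg/kg to 20 mg/kg.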

Compound 4, dose for half-maximal effect: > 50 mg/kg
Compound 4 gave a limit, no number; the forecaster's own chance of this, stated with the estimate: 10%; middle value at least 7.1-fold (0.85 log units) from the limit.
By their numbers in this assay, from the lowest: compound 3; then compounds 2 and 1 (each within the scatter of the next). At a limit, above all of these: compound 4.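

In this assay, this position proves sensitive: closing propylamino into azetidin-1-yl, with the same count of heavy atoms, gives an at least 9.8-fold higher number from compound 3 to compound 4 (0.99 log units; beyond the scatter). Compound 4 has a limit, not a number: the limit of > 50 mg/kg in this assay, at which 1 of the 4 values shown sits. The change adds a ring and also removes the hydrogen-bond donor, and this single step cannot separate the two. Still open, from the compounds shown here alone, is how a dimethylamino group, which has no ring or donor, or a cyclopropylamino group, which has both, would compare with propylamino at this position on the shared core.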